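The source may report more compounds than this note shows. Statements on the series, on what has been measured and on what is new or still open speak of the compounds shown alone.

Of the compounds shown here, two sharing a core have been measured in an ADME assay on cells (Hepatocyte, Rattus norvegicus), with a stated time of 60 min; on this read-out lower numbers stand for a less stable compound and higher numbers for a more stable compound. Compound 1 `O=C1CCC(=O)N1Cc1cc2nccc(-c3cc(Cl)cc4c3O[C@@H](c3onc5c3CNCC5)C4)c2s1` gives 4% in this assay. Compound 2 `O=C1CCC(=O)N1Cc1cc2nccc(-c3cc(Cl)cc4c3O[C@@H](c3ocnc3CN3CCC3)C4)c2s1` gives 2% in this assay, and its number sits beside that of compound 1 within the scatter, so neither can be set apart from the other; both are low on this read-out. Going by the values given here, the only measured step, a number 2 percentage points lower from compound 1 to compound 2 (within the scatter), reached no further than the scatter. Compound 3 `Cn1nc2c(c1[C@H]1Cc3cc(Cl)cc(-c4ccnc5cc(CN6C(=O)CCC6=O)sc45)c3O1)CNCC2` differs from compound 2 in one place: a group of 10 heavy atoms (7 carbon, 3 nitrogen; one five-membered aromatic ring with 2 hetero atoms, one six-membered non-aromatic ring with 1 hetero atom) in place of a group of 10 heavy atoms (7 carbon, 2 nitrogen, 1 oxygen; one four-membered non-aromatic ring with 1 hetero atom, one five-membered aromatic ring with 2 hetero atoms), on a saturated ring carbon. That single step bears on this change, since it also exchanged one of these ring-bearing groups on the same saturated ring carbon, and it produced no movement beyond the scatter. No step beyond the scatter is therefore expected from compound 2 to compound 3 in this assay, a number 2 percentage points higher from compound 2 to compound 3 (within the scatter). Compound 3 is expected to give about 4% in this assay, estimated between 0% and 15%.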

Compound 3, percent of the compound remaining: 42%
For compound 3 the middle estimate is 38 percentage points below the measured one; the measured number lies above the stated range.
By their numbers in this assay, from the lowest: compounds 2 and 1 (each within the scatter of the next); then compound 3.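

In this assay, the saturated ring carbon next to the ring oxygen proves sensitive to the group it carries, which the earlier step within the scatter did not reveal: the replacement of the 4-((azetidin-1-yl)methyl)-1,3-oxazol-5-yl group gives a number 40 percentage points higher from compound 2 to compound 3 (beyond the scatter), and the exchange of the group in compound 1 gives a number 38 percentage points higher from compound 1 to compound 3 (beyond the scatter). A six-membered non-aromatic ring with 1 hetero atom does not by itself go with the higher number, since compound 1 also carries one and goes against that pattern. Nothing available explains the difference.

The compounds shown leave open which part of the entering group carries the difference. They also leave open whether the higher number would persist if an open-chain amine, such as a dimethylaminomethyl group, took the place of its non-aromatic ring.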